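Dropping an aromatic chloro group in a sulfone series

The source may hold more compounds than are shown below. What is called first, only, known or untested is meant among the compounds shown, and "the series" means these compounds.

Measured compounds:
compound 1 `COc1ccc(S(=O)(=O)c2cnc3ccc(F)cc3c2N2CCC(C)CC2)cc1`, 85%
compound 2 `CC1CCN(c2c(S(=O)(=O)c3ccc(F)c(Cl)c3)cnc3c(F)cccc23)CC1`, 95%
compound 3 `COc1ccc(S(=O)(=O)c2cnc3ccc(F)cc3c2N2CCC(C)CC2)cc1Cl`, 82%

All three were tested in an assay on isolated protein for displacement of a labelled ligand from metabotropic glutamate receptor 5 (Homo sapiens), with a stated time of 60 min, tested at 1 uM; a lower number here means less inhibition, a higher number more inhibition at the concentration tested (going by the name of the read-out). Compound 2 gives the highest of the three numbers; its gap to compound 1 lies within the scatter, its gap to compound 3 lies beyond it. Compound 3 and compound 1 differ in one place, described as hydrogen in place of chloro on an aromatic carbon, and the step of a number 3 percentage points higher from compound 3 to compound 1 (within the scatter) is within the scatter, so no change is read from it.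

Compound 4 `CC1CCN(c2c(S(=O)(=O)c3ccc(F)cc3)cnc3c(F)cccc23)CC1` has not yet been measured in this assay. It differs from compound 2 by hydrogen in place of chloro on an aromatic carbon, the same kind of change as that from compound 3 to compound 1, though here the carbon sits ortho to a fluoro group rather than ortho to a methoxy group. The difference between the core of compound 2 and the core of compound 3 is not broken down here.

Because the step of a number 3 percentage points higher from compound 3 to compound 1 (within the scatter) from compound 3 to compound 1 stayed within the scatter, a step of comparable size, a number 6 percentage points lower from compound 2 to compound 4 (within the scatter), is expected from compound 2 to compound 4. Compound 4 is therefore estimated at 89%, between 76% and 98%.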

Compound 4, a percentage reported as inhibition, at one concentration (the size of the read-out at that concentration, not a potency): 26%
Estimate against measurement, compound 4: 63 percentage points above; measured number outside the range, below it.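

In this assay, the loss of the chloro group does not read alike on the two cores: on the core of compound 2 the change gives a large step, a number 69 percentage points lower from compound 2 to compound 4 (beyond the scatter), whereas on the core of compound 3 no change can be read from it. The result of this change on one core therefore does not carry over to the other in this series: the same change on two cores in this assay, a number 3 percentage points higher (within the scatter) from compound 3 to compound 1 and a number 69 percentage points lower (beyond the scatter) from compound 2 to compound 4, 72 percentage points apart, beyond the scatter of two such steps

What the two pairs do not show is which difference sets this gap, since they differ in the core and also in the ring that carries the chloro group, which holds a fluoro group in compound 2 and a methoxy group in compound 3. The compounds shown leave open whether a bromo or a methyl group in place of the chloro group would give a number near that of compound 2, 95%. They also leave open how a methoxy group in place of the fluoro group of compound 4 would read on that core, which would help separate the two differences.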